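The compounds below may be only part of what the source reports. "The series", "measured", "known", "first", "only" and "open" are said of these compounds alone.

Measured so far in an assay on MDA-MB-231 cells for binding affinity to C-X-C chemokine receptor type 4 (Homo sapiens), read by immunofluorescence and microscopy, with stated times of 10 min and 30 min; a higher number here means that more compound is needed for the effect, a lower number that less compound is needed:
- compound 1 `Cc1ccc(S(=O)(=O)NCc2ccc(CNC(=O)c3ccc([N+](=O)[O-])cc3)cc2)cc1`: 10 nM
- compound 2 `COc1ccc(C(=O)NCc2ccc(CNS(=O)(=O)c3ccc(C)cc3)cc2)cc1`: 100 nM
- compound 3 `Cc1ccc(S(=O)(=O)NCc2ccc(CNC(=O)c3cccc(Cl)c3)cc2)cc1`: 100 nM

Compound 3 stands level with compound 2 at the digits printed, the two together giving the highest numbers of the three; the step of a 10-fold higher number from compound 1 to compound 3 (1.00 log units; beyond the scatter) separates it from compound 1, and the step of no change at the digits printed from compound 2 to compound 3 (within the scatter) lies within the scatter.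

Compound 4 `Cc1ccc(S(=O)(=O)NCc2ccc(CNC(=O)c3cccc(F)c3)cc2)cc1` differs from compound 3 by fluoro in place of chloro on an aromatic carbon. For the measured compounds named here, no measured step exchanges one halogen for another, so none bears directly on this change; the steps of a 10-fold higher number from compound 1 to compound 2 (1.00 log units; beyond the scatter) and a 10-fold higher number from compound 1 to compound 3 (1.00 log units; beyond the scatter) concern other groups, and no change at the digits printed from compound 2 to compound 3 (within the scatter) shows a 3-chlorophenyl and a 4-methoxyphenyl giving the same number. A step no larger than the scatter is therefore expected in this assay, no change at the digits printed from compound 3 to compound 4 (within the scatter).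

Compound 4 is estimated at 100 nM, in the range 40 nM to 300 nM.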

Compound 4, effective concentration (reported as EC, without a stated level of effect): 1 nM
For compound 4 the middle estimate is 100-fold (2.00 log units) above the measured one; the whole stated range lies above it.
By their numbers in this assay, from the lowest: compound 4; then compound 1; then compounds 2 and 3 (each within the scatter of the next).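

In this assay, for the compounds shown here, the halogen at this position matters far more than the earlier compounds suggested: the change from 3-chlorophenyl to 3-fluorophenyl gives (a 100-fold lower number from compound 3 to compound 4 (2.00 log units; beyond the scatter)), and this exchange of a single atom exceeds every earlier step. The 3-fluorophenyl group also separates compound 4 from the other two aryl groups (a 100-fold lower number from compound 2 to compound 4 (2.00 log units; beyond the scatter)) and (a 10-fold lower number from compound 1 to compound 4 (1.00 log units; beyond the scatter)), leaving compound 4 with the lowest number of the four. Nothing measured here accounts for the size of the halogen step.

Still open, on these data alone, is where bromo, trifluoromethyl or plain hydrogen in the same place would fall relative to fluoro and chloro. Also open, as far as these compounds go, is whether fluoro keeps this low number at other carbons of the ring.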